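The source may report more compounds than this note shows. Statements on the series, on what has been measured and on what is new or still open speak of the compounds shown alone.

Working notes on the series.

The shared core is carried by compound 1 `CCO/C(O)=C1\C(COCCNC(=O)NC)=NC(C)=C(C(=O)OC)C1c1ccccc1Cl` and compound 2 `CCO/C(O)=C1\C(COCCNS(N)(=O)=O)=NC(C)=C(C(=O)OC)C1c1ccccc1Cl`, which differ only at the amine nitrogen of the side chain. For the measured compounds named here, in a functional assay (aorta) with Rattus norvegicus as the target (a lower number here means a stronger inhibitor, a higher number a weaker inhibitor), compound 1 gives 3.16 nM, the lowest of the two numbers measured so far. Compound 2 gives 7.94 nM in this assay. Going by the values given here, the one measured step, a 2.5-fold higher number from compound 1 to compound 2 (0.40 log units; beyond the scatter), sulfamoyl in place of methylcarbamoyl on the amine nitrogen, sets the only reference point for what a change at that nitrogen does.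

Compound 3 `CCO/C(O)=C1\C(COCCNC(C)(C)C(N)=O)=NC(C)=C(C(=O)OC)C1c1ccccc1Cl` has not yet been measured in this assay. It differs from compound 1 in this way: 1-carbamoyl-1-methylethyl in place of methylcarbamoyl on an amine nitrogen. The step from compound 1 to compound 2 is the only one that bears on it, since it alters the same amine nitrogen; it was modest and went toward a higher number. Among the compounds with values here, the entering group here is a different one, and no other step on this nitrogen exists, so the expectation rests on that single comparison and is loose.

For compound 3 a modest shift toward a higher number is expected, a 2.0-fold higher number from compound 1 to compound 3 (0.30 log units; within the scatter), giving an estimated 6.3 nM with a range from 2.5 nM to 16 nM in this assay.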

Compound 3, half-maximal inhibitory concentration: 3.16 nM
Compound 3: middle estimate off by 2.0-fold (0.30 log units), on the high side, and the stated range covers the measured number.
By their numbers in this assay, from the lowest: compounds 1 and 3 (each within the scatter of the next); then compound 2.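

In this assay, for the compounds shown here, the amine nitrogen takes 1-carbamoyl-1-methylethyl in place of methylcarbamoyl with no change at the digits printed from compound 1 to compound 3 (within the scatter) even though the entering group has more heavy atoms, so a change at this nitrogen does not by itself move the number upward, which the single earlier step could not show. The second new step, a 2.5-fold lower number from compound 2 to compound 3 (0.40 log units; beyond the scatter) on replacing sulfamoyl with 1-carbamoyl-1-methylethyl, leaves compound 2 as the only one of the three that stands apart, and the two carbon-linked or carbonyl-linked groups on compounds 1 and 3 cannot be told apart in this read-out. Nothing available accounts for this pattern in terms of measured properties of the groups.

Still open, from the compounds shown here alone, is whether the number holds when the carbamoyl end of 1-carbamoyl-1-methylethyl gives way to a carboxylic acid or a primary amine, or when its two methyl groups are absent, as in plain carbamoylmethyl. Equally open, going by these compounds, is how a longer chain or a ring-bearing group on this amine nitrogen would read in this assay against the three groups seen so far.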